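Side-chain trim on compound 3: hydroxybutyl to hydroxypropyl

A few compounds are considered here, and "the series" means these few. Any claim that something is new, unique, unknown or untested is made for them only; others in the source may bear on it.

Values in a functional assay on HeLa cells (Homo sapiens) for cytotoxicity, read by MTT assay; a lower number here means a stronger inhibitor, a higher number a weaker inhibitor:
- compound 1 `COC(C)CO[C@H](CC=C(C)C)C1=CC(=O)c2c(O)ccc(O)c2C1=O`: 53400 nM
- compound 2 `CCCCC(O)CC(=O)O[C@H](CC=C(C)C)C1=CC(=O)c2c(O)ccc(O)c2C1=O`: 72200 nM
- compound 3 `CCC(O)CO[C@H](CC=C(C)C)C1=CC(=O)c2c(O)ccc(O)c2C1=O`: 28700 nM

Compound 3, at 28700 nM, cannot be separated from compound 1, given a 1.9-fold lower number from compound 1 to compound 3 (0.27 log units; within the scatter), but stands clear of compound 2, given a 2.5-fold lower number from compound 2 to compound 3 (0.40 log units; beyond the scatter). Compound 4 `CC(C)=CC[C@@H](OCC(C)O)C1=CC(=O)c2c(O)ccc(O)c2C1=O` differs from compound 3 by hydrogen in place of methyl on a saturated chain carbon, two bonds along the chain from an oxygen on a saturated carbon, which turns 2-hydroxybutyl into 2-hydroxypropyl. Within the data shown here, no measured step isolates this change. Among the measured compounds shown here, the closest precedent is the small change in a 1.9-fold lower number from compound 1 to compound 3 (0.27 log units; within the scatter), whereas the larger exchange of (2-hydroxyhexyl)carbonyl gave a 2.5-fold lower number from compound 2 to compound 3 (0.40 log units; beyond the scatter). The expected result is a 1.2-fold higher number from compound 3 to compound 4 (0.09 log units; within the scatter), with no shift beyond the scatter and no firm direction. Compound 4 is estimated at 35000 nM, with an expected range of 15000 nM to 75000 nM.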

Compound 4, half-maximal inhibitory concentration: 24700 nM
Estimate against measurement, compound 4: 1.4-fold (0.15 log units) above, and the stated range covers the measured number.
By their numbers in this assay, from the lowest: compounds 4, 3, 1 and 2 (each within the scatter of the next, the first and the last beyond it).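

In this assay, cutting 2-hydroxybutyl to 2-hydroxypropyl at this position gives no shift beyond the scatter (a 1.2-fold lower number from compound 3 to compound 4 (0.07 log units; within the scatter)), so this methyl can be lost without a measurable change. The 2-hydroxypropyl side chain separates from 2-methoxypropyl (a 2.2-fold lower number from compound 1 to compound 4 (0.33 log units; beyond the scatter)), which 2-hydroxybutyl did not, and it also stands clear of (2-hydroxyhexyl)carbonyl (a 2.9-fold lower number from compound 2 to compound 4 (0.47 log units; beyond the scatter)). No evidence is available that explains these steps.

On these data alone, whether an amine or a carboxylic acid in place of the side-chain hydroxyl would shift the number remains open. So does the effect of a longer chain ending in a phenyl ring on the same oxygen.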